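This account rests on a few compounds, and the source may have more. Where it says the series, first, only, none or still open, it means among the compounds named here.

In an ADME assay on MRC5 cells (Homo sapiens), read by MTT assay, with a stated time of 72 h (a lower number here means a stronger inhibitor, a higher number a weaker inhibitor), the measured compounds give:

Compound 1 `COc1ncnc2c1c(-c1cc3ccccc3o1)cn2[C@@H]1O[C@H](CO)[C@@H](O)[C@H]1O`: 65600 nM
Compound 2 `COc1nc(N)nc2c1c(-c1ccco1)cn2[C@@H]1O[C@H](CO)[C@@H](O)[C@H]1O`: 89700 nM
Compound 3 `COc1nc(N)nc2c1c(-c1cccs1)cn2[C@@H]1O[C@H](CO)[C@@H](O)[C@H]1O`: > 100000 nM, a limit and not a number

Compound 3 is known only through this limit, and it is the limit of > 100000 nM in this assay, at which 1 of the 3 values shown sits. Compound 4 `COc1nc(N)nc2c1c(-c1cc3ccccc3o1)cn2[C@@H]1O[C@H](CO)[C@@H](O)[C@H]1O` changes one group of compound 3: 1-benzofuran-2-yl in place of thiophen-2-yl on an aromatic carbon. The new group, 1-benzofuran-2-yl, replaces thiophen-2-yl on an aromatic carbon of a five-membered aromatic ring with 1 nitrogen.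

Two pieces of data bear on this change. Going by the values given here, the one measured step at this place is an at least 1.1-fold higher number from compound 2 to compound 3 (0.04 log units; that floor lies within the scatter), so it gives no clear size to build on. Compound 1 carries the same 1-benzofuran-2-yl group on a core that differs elsewhere, and compound 1 gives 65600 nM in this assay. On that value, a similar number is expected, which would be a small move towards a lower number, perhaps none beyond the scatter. This estimate means an at least 1.4-fold lower number from compound 3 to compound 4 (0.15 log units; that floor lies within the scatter), an expected step of modest size. Compound 4 is estimated at 70000 nM, with an expected range of 30000 nM to 100000 nM.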

Compound 4, half-maximal inhibitory concentration: 22700 nM
Beside the measured number, compound 4's estimate is 3.1-fold (0.49 log units) above it; the measured number lies below the stated range.
By their numbers in this assay, from the lowest: compound 4; then compounds 1 and 2 (each within the scatter of the next). At a limit, above all of these: compound 3.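

In this assay, 1-benzofuran-2-yl on this aromatic carbon gives a 4.0-fold lower number from compound 2 to compound 4 (0.60 log units; beyond the scatter), so with furan-2-yl as the group replaced, this change moves the number by a clear margin. Compound 3 is known only through a limit, which makes an at least 4.4-fold lower number from compound 3 to compound 4 (0.64 log units; beyond the scatter) a floor and not a measured size: the limit of > 100000 nM in this assay, at which 1 of the 4 values shown sits. The amino group in place of hydrogen, a change elsewhere on the shared core, also shows an effect when 1-benzofuran-2-yl is present: a 2.9-fold lower number from compound 1 to compound 4 (0.46 log units; beyond the scatter).

From the compounds shown here alone, whether the lower number follows from the added six-membered ring stays open, since a plain phenyl group or a 1-benzothiophen-2-yl group would be needed to test that. Going by these compounds, how the amino group behaves alongside furan-2-yl or thiophen-2-yl also remains unknown.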